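The source may hold more compounds than are shown below. What is called first, only, known or untested is meant among the compounds shown, and "the series" means these compounds.

Compound 1 `COc1ccc(-c2cn3cc(C4=CCN(S(=O)(=O)CCc5ccccc5)CC4)ccc3n2)cc1OC` gives 7690 nM in a functional assay on A549 cells (Homo sapiens) for antiproliferative activity, read by MTT assay, with a stated time of 48 h; a lower number here means a stronger inhibitor, a higher number a weaker inhibitor.
Compound 2 `COc1ccc(-c2cn3cc(C4=CCN(C(=O)c5ccccc5C(F)(F)F)CC4)ccc3n2)cc1OC` gives 2550 nM in this assay.
Compound 3 `COc1ccc(-c2cn3cc(C4=CCN(C(=O)C5CCCCC5)CC4)ccc3n2)cc1OC` gives 7310 nM in this assay.

Compound 3 sits alongside compound 1, the two values lying within the scatter of each other, as the step of a 1.1-fold lower number from compound 1 to compound 3 (0.02 log units; within the scatter) shows; both give higher numbers than compound 2, and the step of a 2.9-fold higher number from compound 2 to compound 3 (0.46 log units; beyond the scatter) is beyond the scatter. Compound 4 `COc1ccc(-c2cn3cc(C4=CCN(C(=O)c5ccc(Cl)cc5)CC4)ccc3n2)cc1OC` is not yet measured. It differs from compound 3 by 4-chlorophenyl in place of cyclohexyl on a carbonyl carbon. Going by the values given here, the one measured step that bears directly on this change is a 2.9-fold higher number from compound 2 to compound 3 (0.46 log units; beyond the scatter), where an aromatic ring on the carbonyl carbon went with the lower number; read in the other direction it is modest but beyond the scatter. The step of a 3.0-fold lower number from compound 1 to compound 2 (0.48 log units; beyond the scatter) touches the same amide position more loosely. Compound 4 carries a different aromatic ring than compound 2, so the size of its step is uncertain. Compound 4 is therefore expected to give a number lower than compound 3, by about a 2.1-fold lower number from compound 3 to compound 4 (0.32 log units; beyond the scatter), with an estimate of 3500 nM and a range from 1500 nM to 9000 nM.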

Compound 4, half-maximal inhibitory concentration: 8970 nM
Compound 4: the middle estimate sits 2.6-fold (0.41 log units) below what was measured; the measured number falls inside the stated range.
By their numbers in this assay, from the lowest: compound 2; then compounds 3, 1 and 4 (each within the scatter of the next).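

Replacing cyclohexyl with 4-chlorophenyl on the carbonyl carbon gives a 1.2-fold higher number from compound 3 to compound 4 (0.09 log units; within the scatter) in this assay, so an aromatic ring at this position does not by itself go with the lower number seen for compound 2. The ring's substitution matters here, as 4-chlorophenyl in place of 2-(trifluoromethyl)phenyl gives a 3.5-fold higher number from compound 2 to compound 4 (0.55 log units; beyond the scatter), and among these four compounds only compound 2 stands apart, while the change from the phenethylsulfonyl group gives a 1.2-fold higher number from compound 1 to compound 4 (0.07 log units; within the scatter) and leaves the amide and the sulfonamide unseparated. Nothing given here accounts for these differences.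

From the compounds shown here alone, it remains open whether the lower number of compound 2 belongs to the trifluoromethyl group itself or to the particular ring that carries it. A plain phenyl, a pyridine ring or a ring bearing an amine or a carboxylic acid could help to settle how far this position tolerates change.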